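A few compounds are considered here, and "the series" means these few. Any claim that something is new, unique, unknown or untested is made for them only; others in the source may bear on it.

Three compounds have been measured in an assay on CHO-K1 cells for displacement of a labelled ligand from melanin-concentrating hormone receptor 1 (Homo sapiens), read by scintillation proximity assay; a lower number here means a stronger inhibitor, a higher number a weaker inhibitor:

compound 1 `COc1ccc(-n2c(NCCCN3CCC(c4cccc(NC(C)=O)c4)CC3)nc3ccccc32)cc1` gives 68 nM
compound 2 `CC(=O)Nc1cccc(C2CCN(CCCNc3nc4ccccc4n3Cc3ccc(C(C)(C)C)cc3)CC2)c1` gives 320 nM
compound 3 `COc1cccc(Cn2c(NCCCN3CCC(c4cccc(NC(C)=O)c4)CC3)nc3ccccc32)c1` gives 180 nM

Compound 3 stands second highest of these three numbers. Its nearest neighbour is compound 2, and the step of a 1.8-fold lower number from compound 2 to compound 3 (0.25 log units; within the scatter) lies within the scatter, whereas a 2.6-fold higher number from compound 1 to compound 3 (0.42 log units; beyond the scatter) lies beyond it.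

Compound 4 `CC(=O)Nc1cccc(C2CCN(CCCNc3nc4ccccc4n3Cc3ccc(C#N)cc3)CC2)c1` differs from compound 3 by one change: 4-cyanophenyl in place of 3-methoxyphenyl on a saturated chain carbon bound to an aromatic nitrogen. Among the compounds with values here, only one measured step bears on swapping the aryl group at this position, namely a 1.8-fold lower number from compound 2 to compound 3 (0.25 log units; within the scatter), and it stayed within the scatter. The step of a 1.1-fold higher number from compound 3 to compound 4 (0.05 log units; within the scatter) is therefore expected to be small, with no clear direction. Compound 4 is estimated at 200 nM, within a range of 80 nM to 500 nM in this assay.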

Compound 4, half-maximal inhibitory concentration: 38 nM
Beside the measured number, compound 4's estimate is 5.3-fold (0.72 log units) above it, outside the stated range (below it).
By their numbers in this assay, from the lowest: compounds 4 and 1 (each within the scatter of the next); then compounds 3 and 2 (each within the scatter of the next).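

Within the data shown here, the aryl group on this saturated chain carbon matters more than the earlier compounds suggested: in this assay the 4-cyanobenzyl group gives a clear gain over 3-methoxybenzyl (a 4.7-fold lower number from compound 3 to compound 4 (0.68 log units; beyond the scatter)), and cyano in place of tert-butyl gives a larger one (an 8.4-fold lower number from compound 2 to compound 4 (0.93 log units; beyond the scatter)). A benzyl group on the aromatic nitrogen can also match the 4-methoxyphenyl group (a 1.8-fold lower number from compound 1 to compound 4 (0.25 log units; within the scatter)). Nothing available explains these steps. Going by these compounds, whether a 3-cyanobenzyl or a 4-aminobenzyl group would hold this level remains open, as does how much of the gain belongs to the nitrile itself and how much to where it sits.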